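This account rests on a few compounds, and the source may have more. Where it says the series, first, only, none or still open, it means among the compounds named here.

Working notes on the series. The shared core carries a methyl-substituted aryl amide bearing a triazole, linked through a short chain to a pyrazole that carries a fluoropyridine. In a functional assay on cells for antagonist activity at Orexin/Hypocretin receptor type 1 (Homo sapiens), read by fluorescence and calcium flux, with a stated time of 30 min (on this read-out lower numbers stand for stronger inhibition and higher numbers for weaker inhibition), compound 2, `Cc1ccc(-n2nccn2)c(C(=O)N(C)CCn2ccc(-c3ccc(F)cn3)n2)c1`, gives 5.54 nM. This is the lowest of the three numbers recorded so far. Compound 1, `CCN(C(=O)c1cc(C)ccc1-n1nccn1)[C@H](C)Cn1ccc(-c2ccc(F)cn2)n1`, gives 86.6 nM in this assay, a step that lies beyond the usual scatter. Compound 3, `Cc1ccc(-n2nccn2)c(C(=O)N[C@@H](C)Cn2cc(-c3ccc(F)cn3)cn2)c1`, gives 245 nM in this assay, again beyond the scatter relative to compound 2. Compounds 1 and 3 differ from compound 2 in more than one place each, so no single change can be read off from them.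

Compound 4, `Cc1ccc(-n2nccn2)c(C(=O)N(C)[C@@H](C)Cn2ccc(-c3ccc(F)cn3)n2)c1`, is not yet measured. Relative to compound 2 the change is methyl in place of hydrogen on a saturated chain carbon bound to an amide-type nitrogen and a saturated chain carbon. For the measured compounds named here, no pair of measured compounds differs in only this place, so the size of the step is open. Compound 1 also carries a methyl on the chain, together with an ethyl on the amide nitrogen, and gives 86.6 nM; that combination of two changes is the only hint, and it points toward a weaker read-out. The step from compound 2 to compound 4 is expected to be a 1.8-fold higher number from compound 2 to compound 4 (0.26 log units; within the scatter), toward a somewhat higher number but possibly within the scatter. Compound 4 is expected to give about 10 nM in this assay, with a likely range from 2.5 nM to 40 nM.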

Compound 4, half-maximal inhibitory concentration: 1.9 nM
Beside the measured number, compound 4's estimate is 5.3-fold (0.72 log units) above it, outside the stated range (below it).
By their numbers in this assay, from the lowest: compound 4; then compound 2; then compound 1; then compound 3.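

In this assay, methyl in place of hydrogen on a saturated chain carbon bound to an amide-type nitrogen and a saturated chain carbon gives a 2.9-fold lower number from compound 2 to compound 4 (0.46 log units; beyond the scatter), so this position accepts the added methyl and the read-out moves modestly toward stronger inhibition. For the compounds shown here, this is the first single-place reading at this carbon: compound 4 differs in more than one place from compound 1, which also carries a methyl on the chain, so the higher number that compound 1 gives at 86.6 nM cannot be assigned to the chain methyl, and the weaker direction it hinted at does not hold for the single change. No measurement in hand explains why the added methyl gives this step.

The compounds shown give one single-place reading at this carbon, so it remains open whether the gain extends to a larger group there, such as an ethyl or a hydroxymethyl. Also open, on these data alone, is whether it carries over to other amide substituents or to a longer chain between the amide nitrogen and the pyrazole.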